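The source may report more compounds than this note shows. Statements on the series, on what has been measured and on what is new or still open speak of the compounds shown alone.

Measured in a functional assay on MCF7 cells (Homo sapiens) for antiproliferative activity, read by MTT assay, with a stated time of 72 h; a higher number here means a weaker inhibitor, a lower number a stronger inhibitor:
- Compound 1 `CCNC(=O)c1cc(Oc2ccc(NC(=O)c3nn(-c4ccccc4OC(F)(F)F)c(=O)cc3C)cc2)ccn1`: 15500 nM
- Compound 2 `CCNC(=O)c1cc(Oc2ccc(NC(=O)c3nn(-c4ccc(Br)cc4F)c(=O)cc3C)cc2)ccn1`: 35100 nM
- Compound 3 `CCCNC(=O)c1cc(Oc2ccc(NC(=O)c3nn(-c4ccc(C)cc4)c(=O)cc3C)cc2F)ccn1`: 34600 nM

Compound 2 and compound 3 lie within the scatter of each other at the top of this small set, and compound 1 alone gives a lower number. Compound 4 `CCNC(=O)c1cc(Oc2ccc(NC(=O)c3nn(-c4ccccc4C)c(=O)cc3C)cc2)ccn1` follows from compound 2 through one change, 2-methylphenyl in place of 4-bromo-2-fluorophenyl on an aromatic nitrogen. Within the data shown here, only one measured step touches this group, a 2.3-fold higher number from compound 1 to compound 2 (0.35 log units; beyond the scatter), which brought in the same 4-bromo-2-fluorophenyl in place of 2-(trifluoromethoxy)phenyl. Removing that group again may reverse part of this modest step, so a small move toward a lower number is expected in this assay, a 1.6-fold lower number from compound 2 to compound 4 (0.20 log units; within the scatter). For compound 4 the estimated value is 22000 nM, with an expected range of 10000 nM to 45000 nM.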

Compound 4, half-maximal inhibitory concentration: 44300 nM
Compound 4: the middle estimate sits 2.0-fold (0.30 log units) below what was measured; the range from low to high includes it.
By their numbers in this assay, from the lowest: compound 1; then compounds 3, 2 and 4 (each within the scatter of the next).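

In this assay, 2-methylphenyl in place of 4-bromo-2-fluorophenyl on the aromatic nitrogen gives no separable change (a 1.3-fold higher number from compound 2 to compound 4 (0.10 log units; within the scatter)), so this assay does not tell these two groups apart. Methyl in place of trifluoromethoxy, by contrast, gives a modest step (a 2.9-fold higher number from compound 1 to compound 4 (0.46 log units; beyond the scatter)), leaving compound 1 clear of both compound 2 and compound 4. No measurement here gives a reason for this difference. Going by these compounds, it remains open whether an amine, a carboxylic acid or a longer chain in place of the methyl of compound 4 would move the number.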